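The compounds below may be only part of what the source reports. "The series", "measured", "known", "first", "only" and "open" are said of these compounds alone.

Compound 1 `N[C@H]1CC[C@H](Nc2c(C(=O)NCc3ccc(F)cc3)nc(N3CCCCS3(=O)=O)c3cccnc23)CC1`: in a functional assay on HCT-116 cells (Homo sapiens) for cytotoxicity, read by MTT assay, with a stated time of 72 h (on this read-out lower numbers stand for stronger inhibition and higher numbers for weaker inhibition), compound 1 gives > 10000 nM, which is a limit of the assay and not a number.
Compound 2 `CS(=O)(=O)Oc1c(C(=O)NCc2ccc(F)cc2)nc(Br)c2cccnc12`: in this assay compound 2 gives > 20000 nM, again a limit of the assay rather than a number.
Compound 3 `O=C(NCc1ccc(F)cc1)c1nc(NCCO)c2cccnc2c1O`: in this assay compound 3 gives "not determined" (no result reported).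

Among the three compounds, compound 2 therefore stands at one of two limits: one value sits at the limit of > 10000 nM in this assay, at which 1 of the 3 values shown sits, compound 2 sits at the limit of > 20000 nM in this assay, at which 1 of the 3 values shown sits, and compound 3 has no number at all. Within the data shown here, no compound here has a measured concentration, so no step between measured compounds can be drawn and nothing in the set shows a change that moved activity in either direction.

Compound 4 `NCCNc1c(C(=O)NCc2ccc(F)cc2)nc(Br)c2cccnc12` is the compound still to be measured. It differs from compound 2 in one place: (2-aminoethyl)amino in place of (methylsulfonyl)oxy on an aromatic carbon. With both shown values at limits and nothing to compare, the size of the step from compound 2 to compound 4 in this assay can only be guessed. The expectation is that compound 4 is estimated to stay weak, with a step of an at least 1.3-fold lower number from compound 2 to compound 4 (0.12 log units; that floor lies within the scatter), and a fair chance that only a limit is reported again. Compound 4 is expected to give about 15000 nM, somewhere between 3000 nM and 50000 nM.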

Compound 4, half-maximal inhibitory concentration: > 20000 nM
Compound 4 gave a limit, no number; the forecaster's own chance of this, stated with the estimate: 60%; middle value at least 1.3-fold (0.12 log units) away from the limit.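

In this assay, among these compounds, compound 2 and compound 4 both end at a limit rather than a number, so no step between them can be read. The compounds shown leave open how strongly any of them acts on these cells, and whether (2-aminoethyl)amino in place of (methylsulfonyl)oxy on an aromatic carbon shifts activity in either direction.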